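The compounds below may be only part of what the source reports. "The series", "measured", "known", "first", "only" and "open" are said of these compounds alone.

Compound 2 `O=[N+]([O-])c1ccc2c(c1)CC(NCC1CCN(CCNS(=O)(=O)c3cccc4ccccc34)CC1)CCC2` gives 79 nM in an assay on isolated protein for inhibition of Neuropeptide Y receptor type 5 (Homo sapiens); a lower number here means a stronger inhibitor, a higher number a weaker inhibitor. Among the two numbers shown, compound 2 holds the highest, yet compound 1 `Cc1ccc2c(c1)CC(NCC1CCN(CCNS(=O)(=O)c3cccc4ccccc34)CC1)CCC2` gives 72 nM, and a 1.1-fold higher number from compound 1 to compound 2 (0.04 log units; within the scatter) lies within the scatter. Compound 3 `Nc1ccc2c(c1)CC(NCC1CCN(CCNS(=O)(=O)c3cccc4ccccc34)CC1)CCC2` differs from compound 2 by amino in place of nitro on an aromatic carbon. Among the compounds with values here, the only measured step, a 1.1-fold higher number from compound 1 to compound 2 (0.04 log units; within the scatter), also exchanged a group on that aromatic carbon without moving this assay beyond the scatter, so no step beyond the scatter is expected here. Compound 3 is therefore expected near 80 nM, between 30 nM and 220 nM. This expectation corresponds to a 1.0-fold higher number from compound 2 to compound 3 (0.01 log units; within the scatter).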

Compound 3, half-maximal inhibitory concentration: 52 nM
For compound 3 the middle estimate is 1.5-fold (0.19 log units) above the measured one, and the stated range covers the measured number.
By their numbers in this assay, from the lowest: compounds 3, 1 and 2 (each within the scatter of the next).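

Amino in place of nitro gives a 1.5-fold lower number from compound 2 to compound 3 (0.18 log units; within the scatter) in this assay and amino in place of methyl gives a 1.4-fold lower number from compound 1 to compound 3 (0.14 log units; within the scatter) so neither step leaves the scatter. This aromatic carbon has now carried methyl, nitro and amino with no step beyond the scatter, and amino adds the first hydrogen-bond donor seen there. No evidence on offer explains this tolerance. Still open, on these data alone, is whether a carboxylic acid, a bulkier group such as tert-butyl or a longer chain on this carbon would also stay within the scatter.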